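A few compounds are considered here, and "the series" means these few. Any claim that something is new, unique, unknown or untested is made for them only; others in the source may bear on it.

Four compounds share one core, with variation on a saturated chain carbon bound to an aromatic nitrogen. Compound 1 `Cc1ccc(Cn2c(/C=C3\SC(=S)N(CC(=O)O)C3=O)nc3cc(Cl)ccc32)cc1` gives 38600 nM in a functional assay on A549 cells (Homo sapiens) for cytotoxicity, read by MTT assay, with a stated time of 48 h; a lower number here means a stronger inhibitor, a higher number a weaker inhibitor. Compound 3 `O=C(O)CN1C(=O)/C(=C/c2nc3cc(Cl)ccc3n2Cc2ccccc2F)SC1=S` gives 5640 nM in this assay; the change between them is 2-fluorophenyl in place of 4-methylphenyl on a saturated chain carbon bound to an aromatic nitrogen, and it made a step of a 6.8-fold lower number from compound 1 to compound 3 (0.84 log units; beyond the scatter). Compound 2 `Cc1ccc(Cn2c(/C=C3\SC(=S)NC3=O)nc3ccccc32)cc1` gives 5310 nM in this assay; its number and that of compound 3 lie within the scatter of each other, while compound 1 sits further off. The difference between the core of compound 2 and the core of compound 1 is not broken down here. Compound 4 `O=C1NC(=S)S/C1=C\c1nc2ccccc2n1Cc1ccccc1F` is not yet measured in this assay. It is related to compound 2 by 2-fluorophenyl in place of 4-methylphenyl on a saturated chain carbon bound to an aromatic nitrogen, the same change that took compound 1 to compound 3, at the same place. The step from compound 2 to compound 4 is expected to be a 3.5-fold lower number from compound 2 to compound 4 (0.55 log units; beyond the scatter), beside the earlier 6.8-fold lower number from compound 1 to compound 3 (0.84 log units; beyond the scatter). It is set somewhat smaller because the earlier step of a 6.8-fold lower number from compound 1 to compound 3 (0.84 log units; beyond the scatter) was seen once only, on a different core. For compound 4 the expected value is 1500 nM, within a range of 500 nM to 5000 nM.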

Compound 4, half-maximal inhibitory concentration: > 50000 nM
Compound 4: a limit, no number; the forecaster's own chance of this, stated with the estimate: 3%; at least 33-fold (1.52 log units) between middle value and limit.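

In this assay compound 4 gives > 50000 nM, a limit of the assay and not a number. The change from 4-methylbenzyl to 2-fluorobenzyl now reads as an at least 9.4-fold higher number from compound 2 to compound 4 (0.97 log units; beyond the scatter), which runs opposite to the step on the other core, and the two steps do not agree: the same change on two cores in this assay, a 6.8-fold lower number (0.84 log units; beyond the scatter) from compound 1 to compound 3 and an at least 9.4-fold higher number (0.97 log units; beyond the scatter) from compound 2 to compound 4, at least 64-fold (1.80 log units) apart, beyond the scatter of two such steps So the change does not carry over from the core of compound 1 to the core of compound 2, though this rests on a single pair on each core, one of them ending in a limit, and it gives neither the full size of the gap nor any rule for other cores.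

The core of compound 1 and the core of compound 2 differ in more than one place, and no pair shown separates those differences, so it stays open which of them goes with the opposite steps. Also open, on these data alone, is how either core responds when an amine or a longer chain stands on the saturated chain carbon bound to the aromatic nitrogen.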